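The compounds below may be only part of what the source reports. "The series", "measured", "known", "first", "only" and "open" are said of these compounds alone.

Measured so far:
Compound 1, `Cc1cn([C@H]2CO[C@@H](COC(=O)C3CCCCC3)O2)c(=O)[nH]c1=O`: in an ADME assay on CCRF-CEM cells (Homo sapiens) for cytotoxicity, read by MTT assay, with a stated time of 3 days (a higher number here means a weaker inhibitor, a lower number a stronger inhibitor), compound 1 gives > 100000 nM, which is a limit of the assay and not a number.
Compound 2, `CCCCC(=O)OC[C@@H]1OC[C@H](n2cc(C)c(=O)[nH]c2=O)O1`: in this assay compound 2 gives > 100000 nM, again a limit of the assay rather than a number.

Compound 2 therefore stands at the edge of what this assay can report, and nothing places it above or below compound 1.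

Compound 3, `Cc1cn([C@H]2CO[C@@H](COC(=O)C3CC3)O2)c(=O)[nH]c1=O`, is still to be measured in this assay. It differs from compound 2 in one place: cyclopropyl in place of butyl on a carbonyl carbon; the same difference, cut one bond further out, reads butylcarbonyl to cyclopropylcarbonyl.

Among the measured compounds shown here, the only measured step at this position is a step that the two limits leave unreadable from compound 1 to compound 2, where a ring gave way to a chain on the same carbonyl carbon. Both ends of that step sit at the limit of > 100000 nM in this assay, at which 2 of the 2 values shown sit, so its size cannot be read, and no direction can be taken from it.

Compound 3 is expected to show a number no higher from compound 2 to compound 3 (the limit leaves the size open), that is, nothing beyond the scatter. Compound 3 is estimated at 100000 nM, within 30000 nM to 300000 nM, and most probably reported only as a limit again.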

Compound 3, half-maximal inhibitory concentration: > 100000 nM
Compound 3: only a limit was reported; the forecaster's own chance of this, stated with the estimate: 85%; the middle value sits exactly at the limit.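

In this assay compound 3 gives > 100000 nM, again a limit of the assay and not a number. Among the compounds shown here, no step among compound 1, compound 2 and compound 3 can be read, in size or in direction: the limit of > 100000 nM in this assay, at which 3 of the 3 values shown sit. The compounds shown leave open whether cyclohexyl, butyl and cyclopropyl on the carbonyl carbon differ at all in this assay.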